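Swapping a thioether for a benzylamine on a shared core

The source may report more compounds than this note shows. Statements on the series, on what has been measured and on what is new or still open speak of the compounds shown alone.

Three compounds have been measured in a functional assay on U-251 cells (Homo sapiens) for inhibition, read by sulforhodamine B assay, with a stated time of 48 h; a higher number here means a weaker inhibitor of growth, a lower number a stronger inhibitor of growth:

compound 1, `CCOC(=O)[C@H](CCC(=O)O)NC(=O)c1ccc(Sc2nc3cc(N)cc(N)c3nc2-c2ccccc2)cc1`, gives 14500 nM
compound 2, `Nc1cc(N)c2nc(-c3ccccc3)c(Sc3ccc(F)cc3)nc2c1`, gives 16200 nM
compound 3, `CCOC(=O)[C@H](CCC(=O)O)NC(=O)c1ccc(CNc2nc3cc(N)cc(N)c3nc2-c2ccccc2)cc1`, gives only a limit, < 100000 nM, not a number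

Compound 2 stands highest of the two numbers, with compound 1 the nearest, and the gap between them lies within the scatter, so nothing separates them. The only other entry is the limit at which compound 3 sits, (the limit of < 100000 nM in this assay, at which 1 of the 3 values shown sits).

Compound 4, `Nc1cc(N)c2nc(-c3ccccc3)c(NCc3ccc(F)cc3)nc2c1`, is still to be measured in this assay. It differs from compound 2 in one place: (4-fluorobenzyl)amino in place of (4-fluorophenyl)sulfanyl on an aromatic carbon. Compound 3 carries the same (4-fluorobenzyl)amino group in place of the sulfanyl link found in compound 1, and its result is a limit rather than a number. On that basis a step of a 2.5-fold higher number from compound 2 to compound 4 (0.39 log units; beyond the scatter) is expected in this assay, towards a higher number, and the estimate for compound 4 in this assay is 40000 nM, between 12000 nM and 100000 nM.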

Compound 4, concentration for 50% growth inhibition: 1580 nM
Beside the measured number, compound 4's estimate is 25-fold (1.40 log units) above it; measured number outside the range, below it.
By their numbers in this assay, from the lowest: compound 4; then compounds 1 and 2 (each within the scatter of the next).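

In this assay, (4-fluorobenzyl)amino in place of (4-fluorophenyl)sulfanyl gives a 10-fold lower number from compound 2 to compound 4 (1.01 log units; beyond the scatter). This shows that the aromatic carbon next to the ring nitrogen and ortho to a phenyl group responds strongly to a change of the group it carries, something compounds 1 and 2 could not show, since their values lie within the scatter of each other. Compound 3 has the same kind of change from compound 1, but its entry is a limit and not a number, so that step cannot be read and the size of the change is known only on the simpler pair: the limit of < 100000 nM in this assay, at which 1 of the 4 values shown sits.

The compounds shown leave open whether the nitrogen of the link or its longer chain carries the step. A benzylsulfanyl group or a directly attached anilino group at this position would separate the two.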